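Pyrimidine nucleotide series: amino in place of ethylsulfanyl

The source may hold more compounds than are shown below. What is called first, only, known or untested is meant among the compounds shown, and "the series" means these compounds.

Measured so far:
compound 1 `O=c1[nH]c(=S)ccn1[C@@H]1O[C@H](COP(=O)(O)O)[C@@H](O)[C@H]1O`: > 100000 nM
compound 2 `CSc1nc(=O)ccn1[C@@H]1O[C@H](COP(=O)(O)OP(=O)(O)O)[C@@H](O)[C@H]1O`: 523 nM
compound 3 `CCSc1nc(=O)ccn1[C@@H]1O[C@H](COP(=O)(O)O)[C@@H](O)[C@H]1O`: 1500 nM

In an in vitro functional assay on 1321-N1 cells for agonist activity at P2Y purinoceptor 2 (Homo sapiens), read by scintillation proximity assay and inositol phosphate accumulation (on this read-out lower numbers stand for an effect already at smaller amounts and higher numbers for an effect only at larger amounts of compound), compound 3 gives 1500 nM and stands as the higher of the two numbers. Compound 2 gives 523 nM in this assay, a gap beyond the usual scatter. The value of compound 1 is only a limit of this assay, not a number (the limit of > 100000 nM in this assay, at which 1 of the 3 values shown sits).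

Compound 4 `Nc1nc(=O)ccn1[C@@H]1O[C@H](COP(=O)(O)O)[C@@H](O)[C@H]1O` differs from compound 3 in one respect: amino in place of ethylsulfanyl on an aromatic carbon. For the measured compounds named here, no measured pair shows this same change, so the step has no direct anchor. The step is expected to go toward larger amounts, beyond the scatter, as a 5.3-fold higher number from compound 3 to compound 4 (0.73 log units; beyond the scatter). Compound 4 is therefore estimated at 8000 nM, within a range of 2000 nM to 40000 nM.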

Compound 4, half-maximal effective concentration: > 100000 nM
Compound 4: no number, only a limit (the forecaster's own chance of this, stated with the estimate: 30%); middle value at least 12-fold (1.09 log units) from the limit.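

Replacing ethylsulfanyl with amino on this aromatic carbon, between two ring nitrogen atoms, gives an at least 66-fold higher number from compound 3 to compound 4 (1.82 log units; beyond the scatter). This is the only single-place change shown, and it makes the substituent here decisive for a measurable number in this assay when the monophosphate is held constant. Compound 4 gives only an assay limit, not a number, and joins compound 1 there: the limit of > 100000 nM in this assay, at which 2 of the 4 values shown sit.

As far as these compounds go, it remains open whether the step depends on losing the sulfur or on introducing the amino group. How a methylamino group or a longer alkylsulfanyl chain would read on this monophosphate is also unresolved.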